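This account rests on a few compounds, and the source may have more. Where it says the series, first, only, none or still open, it means among the compounds named here.

The series shares a core in which a saturated carbon carries a side chain and is tested in a functional assay on HEK293 cells for agonist activity at G-protein coupled receptor 39 (Homo sapiens), read by scintillation proximity assay and inositol phosphate accumulation, with a stated time of 75 min; a lower number here means that less compound is needed, a higher number that more compound is needed for the effect. Compound 2 `Cc1nn(-c2ncnc3nc[nH]c23)c2c1C(OCc1ccc(F)cc1)CC(=O)N2` gives 126 nM and stands at the lowest of the two numbers shown. Its nearest neighbour is compound 1 `Cc1nn(-c2ncnc3nc[nH]c23)c2c1C(C(=O)NCc1ccc(F)cc1)CC(=O)N2`, which gives 1220 nM, a higher number that lies beyond the usual scatter. Compound 3 `Cc1cc(C)nc(-n2nc(C)c3c2NC(=O)CC3c2ccc(F)cc2F)n1` reaches only a limit of this assay, reported as > 10000 nM; one of the three values sits at that limit (the limit of > 10000 nM in this assay, at which 1 of the 3 values shown sits). Within the data shown here, no pair of measured compounds differs in a single place, so no measured step is available to guide the next change.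

Compound 4 `Cc1nn(-c2ncnc3nc[nH]c23)c2c1C(OCC(C)C)CC(=O)N2` differs from compound 2 by isopropyl in place of 4-fluorophenyl on a saturated chain carbon bound to an oxygen on a saturated carbon. Among the measured compounds shown here, nothing among the measured compounds tests such an exchange directly. The step from compound 2 is expected to move toward a higher number, beyond the scatter, as a 4.0-fold higher number from compound 2 to compound 4 (0.60 log units; beyond the scatter). Compound 4 is therefore estimated at 500 nM, with a likely range from 120 nM to 2500 nM.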

Compound 4, half-maximal effective concentration: 111 nM
Compound 4: middle estimate off by 4.5-fold (0.65 log units), on the high side, outside the stated range (below it).
By their numbers in this assay, from the lowest: compounds 4 and 2 (each within the scatter of the next); then compound 1. At a limit, above all of these: compound 3.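

In this assay, among these compounds, the exchange of 4-fluorophenyl for isopropyl on a saturated chain carbon bound to an oxygen on a saturated carbon gives a 1.1-fold lower number from compound 2 to compound 4 (0.06 log units; within the scatter) and is the first step that changes one place only. At this position, 4-fluorobenzyl on the oxygen can thus give way to isobutyl, losing the six-membered aromatic ring, with no change beyond the scatter. Nothing measured here explains why the two groups give matching results.

The compounds shown leave open how a shorter chain such as ethyl, or a chain ending in an amine or a carboxylic acid, would read at this position. Going by these compounds, whether the oxygen itself could be replaced by a plain methylene carbon also remains open.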